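Trimethoxyphenyl pyrazole enones: methoxy loss and growth inhibition

This account rests on a few compounds, and the source may have more. Where it says the series, first, only, none or still open, it means among the compounds named here.

In a functional assay on MCF7 cells (Homo sapiens) for inhibition, read by sulforhodamine B assay, with a stated time of 48 h (on this read-out higher numbers stand for weaker inhibition of growth and lower numbers for stronger inhibition of growth), compound 1 `COc1cc(-c2cc(/C=C/C(=O)c3ccc(N)cc3)[nH]n2)cc(OC)c1OC` gives 1500 nM and compound 2 `COc1ccc(-c2cc(/C=C/C(=O)c3ccc(N)cc3)[nH]n2)cc1OC` gives 2280 nM. The step of a 1.5-fold higher number from compound 1 to compound 2 (0.18 log units; within the scatter) is hydrogen in place of methoxy on an aromatic carbon. Compound 3 `COc1cc(C(=O)/C=C/c2cc(-c3cc(OC)c(OC)c(OC)c3)n[nH]2)cc(OC)c1OC` gives 640 nM in this assay, the lowest number of the three measured; the difference between the core of compound 3 and the core of compound 1 is not broken down here. Compound 4 `COc1ccc(-c2cc(/C=C/C(=O)c3cc(OC)c(OC)c(OC)c3)[nH]n2)cc1OC` is still to be measured in this assay. Its change from compound 3 is hydrogen in place of methoxy on an aromatic carbon, the same structural change as from compound 1 to compound 2. The expected step of a 1.5-fold higher number from compound 3 to compound 4 (0.17 log units; within the scatter) is estimated to be of similar size to that earlier one, because the only shown instance of this change, a 1.5-fold higher number from compound 1 to compound 2 (0.18 log units; within the scatter), stayed within the scatter. Compound 4 is therefore expected to give about 950 nM, with a range of 400 nM to 2200 nM.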

Compound 4, concentration for 50% growth inhibition: 1060 nM
Compound 4: middle estimate off by 1.1-fold (0.05 log units), on the low side; measured number inside the range.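

In this assay, hydrogen in place of methoxy on an aromatic carbon gives a 1.7-fold higher number from compound 3 to compound 4 (0.22 log units; within the scatter). Set beside the earlier instance, the change carries from one core to the other with no difference in size that can be told apart: the same change on two cores in this assay, a 1.5-fold higher number (0.18 log units; within the scatter) from compound 1 to compound 2 and a 1.7-fold higher number (0.22 log units; within the scatter) from compound 3 to compound 4, 1.1-fold (0.04 log units) apart, within the scatter of two such steps. Each step lies within the scatter, so neither shows on its own that losing this methoxy affects growth inhibition, and two cores give no rule for other cores in the series.

Left open is what a group other than methoxy or hydrogen would do on this aromatic carbon, for example hydroxyl, fluorine or ethoxy. Also open, from the compounds shown here alone, is whether the same small step would appear on a third core.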